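This account rests on a few compounds, and the source may have more. Where it says the series, first, only, none or still open, it means among the compounds named here.

Compound 1 `COc1ccc(CNC(=O)c2cc(-c3cncc(C)c3)ncc2-c2cnccn2)nc1OC`: 10000 nM
Compound 2 `COc1ccc(CNC(=O)c2nc(-c3cncc(C)c3)cnc2-c2ccccc2)nc1OC`: > 20000 nM
Compound 3 `COc1ccc(CNC(=O)c2cc(-c3cncc(C)c3)ncc2-c2ccccc2F)nc1OC`: not yet measured

Of the compounds shown here, two have been measured in an assay on CHO cells for antagonist activity at Orexin/Hypocretin receptor type 1 variant I408V (Homo sapiens), read by FLIPR, with a stated time of 5 min (a higher number here means a weaker inhibitor, a lower number a stronger inhibitor), and one more awaits testing. Compound 1 gives 10000 nM in this assay, the only full number shown. For compound 2 this assay reports only a limit, > 20000 nM; this is the limit of > 20000 nM in this assay, at which 1 of the 2 values shown sits, and no number stands behind it. Compound 1 therefore stands as the single fixed point against which the unmeasured compound can be judged.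

Compound 3 differs from compound 1 in one place: 2-fluorophenyl in place of pyrazin-2-yl on an aromatic carbon. The change sits on an aromatic carbon of the shared core, ortho to a large group and para to the 5-methylpyridin-3-yl group. Among the measured compounds shown here, since no measured pair shows this kind of exchange, nothing shows how large a step in this assay it should bring, and the expectation rests on the structural change alone. The step from compound 1 to compound 3 is expected to be modest, toward a somewhat stronger inhibitor, as a 3.3-fold lower number from compound 1 to compound 3 (0.52 log units; beyond the scatter). For compound 3 the estimate in this assay is 3000 nM, with a range from 500 nM to 20000 nM.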

Compound 3, half-maximal inhibitory concentration: 3000 nM
Estimate against measurement, compound 3: no gap at the digits printed, within the range that was stated.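

At this position on the shared core, an aromatic carbon ortho to a large group and para to a 5-methylpyridin-3-yl group, exchanging pyrazin-2-yl for 2-fluorophenyl brings a 3.3-fold lower number from compound 1 to compound 3 (0.52 log units; beyond the scatter) in this assay and gives the first measured sign that the group here affects the read-out. The entering ring is of carbon only and has 0 hydrogen-bond acceptors against the 2 of pyrazin-2-yl, so the ring nitrogens of pyrazin-2-yl are not required to reach this level, although compound 3 still gives a high number of 3000 nM in absolute terms. Nothing shown gives a cause for this step.

On these data alone, what stays open is whether the step belongs to the fluorine or to the carbon-only ring, a question that plain phenyl or 2-chlorophenyl at this position would address. Also open, as far as these compounds go, is how a non-aromatic group such as morpholine or a simple amine would read here in this assay, and whether any group at this position can bring the number much lower.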